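Lengthening the basic side chain of compound 2

The source may hold more compounds than are shown below. What is called first, only, known or untested is meant among the compounds shown, and "the series" means these compounds.

Compound 1 `CON/C(=N\C1=NC(=O)C(=O)N1C(C)C)Nc1ccc(Cl)c(Cl)c1`: > 1 h, a limit
Compound 2 `CC(C)N1C(=O)C(=O)N=C1/N=C(\NCCN(C)C)Nc1ccc(Cl)c(Cl)c1`: > 1 h, a limit

In an in vitro ADME assay on microsomes from liver (Homo sapiens) for metabolic stability, read by LC-MS (on this read-out lower numbers stand for a shorter-lived compound and higher numbers for a longer-lived compound), compound 2 gives > 1 h, which is a limit and not a number. Compound 1 also gives only a limit, > 1 h. The data therefore consist of the limit of > 1 h in this assay, at which 2 of the 2 values shown sit, and compound 2 cannot be ranked against compound 1.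

Compound 3 `CC(C)N1C(=O)C(=O)N=C1/N=C(\NCCCN(C)C)Nc1ccc(Cl)c(Cl)c1` differs from compound 2 by (dimethylamino)methyl in place of dimethylamino on a saturated chain carbon, two bonds along the chain from an amine nitrogen. In other words, 2-(dimethylamino)ethyl becomes 3-(dimethylamino)propyl. For the measured compounds named here, the only measured step that bears on this change is a step that the two limits leave unreadable from compound 1 to compound 2, and it offers no size to carry over. No change beyond the scatter is expected in this assay, in either direction. The expected step is a step that the limit leaves unreadable from compound 2 to compound 3. For compound 3 the estimated half-life is 1.5 h, with an expected range of 0.8 h to 3 h.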

Compound 3, half-life: > 1 h
Compound 3: no number, only a limit; the forecaster's own chance of this, stated with the estimate: 75%; the middle value lies beyond the limit too.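

No step can be read among compound 1, compound 2 and compound 3, whose results are all limits and not numbers: the limit of > 1 h in this assay, at which 3 of the 3 values shown sit. From the compounds shown here alone, how long each compound actually lasts in this assay, and whether 3-(dimethylamino)propyl differs there from 2-(dimethylamino)ethyl, remains open.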